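The compounds below may be only part of what the source reports. "The series", "measured", "known", "first", "only" and "open" are said of these compounds alone.

Four compounds built on a shared core were examined in a functional assay on A549 cells (Homo sapiens) for antiproliferative activity, read by MTT assay, with a stated time of 72 h; a lower number here means a stronger inhibitor, a higher number a weaker inhibitor. Compound 1 `COc1cc(C(=O)c2sc3ccccc3c2-c2ccccc2)cc(OC)c1OC` gives 5000 nM in this assay. Compound 2 `COc1cc(C(=O)c2sc3ccccc3c2-c2ccc(Cl)cc2)cc(OC)c1OC` differs from it by chloro in place of hydrogen on an aromatic carbon, and the step of a 1.5-fold higher number from compound 1 to compound 2 (0.18 log units; within the scatter). Compound 3 `COc1cc(C(=O)c2sc3ccccc3c2Nc2ccccc2)cc(OC)c1OC` differs from compound 1 in the core itself: anilino in place of phenyl on an aromatic carbon. In this assay compound 3 gives 3000 nM, while compound 2 gives 7500 nM. The step of a 1.7-fold lower number from compound 1 to compound 3 (0.22 log units; within the scatter), whereas a 2.5-fold lower number from compound 2 to compound 3 (0.40 log units; beyond the scatter), so compound 3 stands apart from compound 2 but not from compound 1.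

Compound 4 `COc1cc(C(=O)c2sc3ccccc3c2Nc2ccc(Cl)cc2)cc(OC)c1OC` has not yet been measured in this assay. It differs from compound 3 by chloro in place of hydrogen on an aromatic carbon. This is the same kind of change as that made between compound 1 and compound 2, and its place is described in the same words; cut one bond further out, however, it reads anilino to (4-chlorophenyl)amino rather than phenyl to 4-chlorophenyl, and the core on which it sits differs in the way told for compound 1 and compound 3. The expectation for compound 4 rests on the earlier step, a 1.5-fold higher number from compound 1 to compound 2 (0.18 log units; within the scatter), which stayed within the scatter. A step of similar size is therefore expected, a 1.5-fold higher number from compound 3 to compound 4 (0.18 log units; within the scatter). Compound 4 is estimated to give 4500 nM in this assay, most likely falling between 2000 nM and 10000 nM.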

Compound 4, half-maximal inhibitory concentration: 3100 nM
For compound 4 the middle estimate is 1.5-fold (0.16 log units) above the measured one; measured number inside the range.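

In this assay, chloro in place of hydrogen on the core of compound 3 gives a 1.0-fold higher number from compound 3 to compound 4 (0.01 log units; within the scatter), so compound 3 and compound 4 cannot be told apart, and this step does not differ from the one made on the core of compound 1: the same change on two cores in this assay, a 1.5-fold higher number (0.18 log units; within the scatter) from compound 1 to compound 2 and a 1.0-fold higher number (0.01 log units; within the scatter) from compound 3 to compound 4, 1.5-fold (0.16 log units) apart, within the scatter of two such steps. Compound 4 stands apart from compound 2, with a 2.4-fold lower number from compound 2 to compound 4 (0.38 log units; beyond the scatter), but not from compound 1, with a 1.6-fold lower number from compound 1 to compound 4 (0.21 log units; within the scatter), so the separation seen earlier between compound 2 and compound 3 also holds for compound 4. The series thus shows that this chloro can be carried from one core to the other without a step beyond the scatter, but, with both steps inside the scatter, it does not show that chloro has any real effect on either core, nor does a pair of cores establish a rule for others.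

The compounds shown leave open whether a fluoro, a methoxy or a carboxylic acid at the same place would separate from hydrogen on these two cores. They also leave open how such groups would read with an ether oxygen or a methylene in place of the amino link.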